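The source may report more compounds than this note shows. Statements on the series, on what has been measured and on what is new or still open speak of the compounds shown alone.

Compound 1 `O=C1N=C(N2CCC[C@H]2C(=O)Nc2ccc3ncnc(Nc4cccc(Cl)c4)c3c2)S/C1=C/c1ccc(Br)s1` and compound 2 `Cc1cccc(/C=C2/SC(N3CCC[C@H]3C(=O)Nc3ccc4ncnc(Nc5cccc(Cl)c5)c4c3)=NC2=O)n1` share one core and differ only in the aryl group on a double-bonded chain carbon bound to a double-bonded ring carbon. In a functional assay on A549 cells (Homo sapiens) for antiproliferative activity, read by MTT assay (on this read-out lower numbers stand for stronger inhibition and higher numbers for weaker inhibition), compound 1 gives only a limit, > 50000 nM. In this assay compound 2 gives 8500 nM, the sole number shown. That change, an at least 5.8-fold lower number from compound 1 to compound 2 (0.76 log units; beyond the scatter), bears directly on compound 3 `O=C1N=C(N2CCC[C@H]2C(=O)Nc2ccc3ncnc(Nc4cccc(Cl)c4)c3c2)S/C1=C/c1cccc(Br)c1`, which carries 3-bromophenyl in place of 6-methylpyridin-2-yl on a double-bonded chain carbon bound to a double-bonded ring carbon. Since compound 1 sits at the limit (the limit of > 50000 nM in this assay, at which 1 of the 2 values shown sits), a move back toward weaker inhibition is expected, a 3.5-fold higher number from compound 2 to compound 3 (0.55 log units; beyond the scatter). Compound 3 is therefore estimated at 30000 nM, between 8000 nM and 100000 nM.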

Compound 3, half-maximal inhibitory concentration: > 50000 nM
Compound 3 gave a limit, no number (the forecaster's own chance of this, stated with the estimate: 45%); middle value at least 1.6-fold (0.22 log units) away from the limit.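

In this assay, replacing the 6-methylpyridin-2-yl group at this place with 3-bromophenyl gives an at least 5.8-fold higher number from compound 2 to compound 3 (0.76 log units; beyond the scatter), so the weak result of compound 1 is not confined to its 5-bromothiophen-2-yl group. Going by these compounds alone, the six-membered ring of carbon only in compound 3 also ends at a limit, and compound 2 remains the only one with a readable number: the limit of > 50000 nM in this assay, at which 2 of the 3 values shown sit. The step from compound 1 to compound 3 cannot be read, as both values are limits.

As far as these compounds go, it remains open whether the ring nitrogen or the methyl group of compound 2 accounts for the difference. A pyridin-2-yl without the methyl, or a 3-methylphenyl, would separate the two.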